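This account rests on a few compounds, and the source may have more. Where it says the series, first, only, none or still open, it means among the compounds named here.

Compounds measured in an assay on HEK293 cells for agonist activity at transient receptor potential cation channel subfamily M member 8 (Homo sapiens), read by fluorescence and calcium flux, with a stated time of 15 min; on this read-out higher numbers stand for an effect only at larger amounts of compound and lower numbers for an effect already at smaller amounts:
- compound 1 `CCN(Cc1cccs1)C(=O)COc1ccc(C)cc1`: 8 nM
- compound 2 `Cc1ccc(OCC(=O)N(Cc2cccs2)c2cccnc2)cc1`: 198 nM
- compound 3 `Cc1ccc(OCC(=O)N(Cc2cccs2)c2ccn(C)n2)cc1`: 855 nM

Compound 3 stands highest of the three numbers in this assay. Its nearest neighbour is compound 2, at a 4.3-fold higher number from compound 2 to compound 3 (0.64 log units; beyond the scatter); its furthest is compound 1, at a 110-fold higher number from compound 1 to compound 3 (2.03 log units; beyond the scatter). Replacing ethyl on the amide-type nitrogen by an aromatic ring cost in both recorded cases: a 25-fold higher number from compound 1 to compound 2 (1.39 log units; beyond the scatter) and a 110-fold higher number from compound 1 to compound 3 (2.03 log units; beyond the scatter). Between the two aromatic substituents themselves the gap was smaller but still beyond scatter: a 4.3-fold higher number from compound 2 to compound 3 (0.64 log units; beyond the scatter).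

Compound 4 `Cc1ccc(OCC(=O)N(Cc2cccs2)c2ncco2)cc1` is not yet measured. Its change from compound 3 is 1,3-oxazol-2-yl in place of 1-methyl-1H-pyrazol-3-yl on an amide-type nitrogen. The entering group is again a five-membered aromatic ring with two hetero atoms, two acceptors and no donor, so the relevant precedent is the step between the two aromatic substituents, a 4.3-fold higher number from compound 2 to compound 3 (0.64 log units; beyond the scatter), which was modest. The large steps from ethyl involve no such exchange between two aromatic rings and are not taken as a guide here. Among the compounds with values here, no step in the set compares two five-membered rings directly, so the direction is uncertain. Compound 4 is therefore expected to give a number within the scatter of compound 3, a 1.1-fold higher number from compound 3 to compound 4 (0.02 log units; within the scatter), with an estimated value of 900 nM and a range of 300 nM to 3000 nM in this assay.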

Compound 4, half-maximal effective concentration: 0.3 nM
Compound 4: the middle estimate sits 3000-fold (3.48 log units) above what was measured; the measured number lies below the stated range.
By their numbers in this assay, from the lowest: compound 4; then compound 1; then compound 2; then compound 3.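

In this assay, within the data shown here, the place on the amide-type nitrogen proves far more sensitive than the earlier compounds indicated: exchanging one five-membered aromatic ring with 2 hetero atoms for another, with the same donor and acceptor counts, gives a 2900-fold lower number from compound 3 to compound 4 (3.45 log units; beyond the scatter). The 1,3-oxazol-2-yl group also separates sharply from pyridin-3-yl, with a 660-fold lower number from compound 2 to compound 4 (2.82 log units; beyond the scatter), and it outperforms ethyl, with a 27-fold lower number from compound 1 to compound 4 (1.43 log units; beyond the scatter), so the earlier loss on moving from ethyl to an aromatic ring holds for pyridin-3-yl and 1-methyl-1H-pyrazol-3-yl but not for every aromatic ring at this place. No measurement available here accounts for the gap between these two five-membered rings.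

Still open, as far as these compounds go, is whether the low number is particular to 1,3-oxazol-2-yl or extends to related groups such as 1,3-thiazol-2-yl or 1,3,4-oxadiazol-2-yl on the same nitrogen. Also open, from the compounds shown here alone, is whether 1,3-oxazol-2-yl keeps this standing when the rest of the core of compound 4 is changed, for instance when the methyl group is replaced by chlorine.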